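Trihalophenyl tetrazoles: fluoro to chloro on the aryl ring

The source may hold more compounds than are shown below. What is called first, only, known or untested is meant among the compounds shown, and "the series" means these compounds.

Two compounds of the series carry numbers in an in vitro functional assay on 1321-N1 cells for antagonist activity at P2X purinoceptor 7 (Homo sapiens), read by FLIPR and calcium flux; a higher number here means a weaker inhibitor, a lower number a stronger inhibitor. Compound 1 `Cc1noc(C)c1Cn1nnnc1-c1cccc(Cl)c1Cl` gives 158 nM in this assay. Compound 2 `Fc1ccc(-c2nnnn2Cc2cccnc2)c(Cl)c1Cl` gives 12.6 nM in this assay, the lower of the two numbers; the gap to compound 1 lies beyond the usual scatter, so compound 2 is the stronger inhibitor of the pair. Compound 3 `Clc1ccc(-c2nnnn2Cc2cccnc2)c(Cl)c1Cl` is not yet measured. It differs from compound 2 in one place: chloro in place of fluoro on an aromatic carbon. Within the data shown here, no step of this kind between measured compounds is available, so the expectation rests on compound 2 alone. The change is expected to move the number little, if at all, within the scatter of this assay; the estimated step from compound 2 to compound 3 is a 1.2-fold higher number from compound 2 to compound 3 (0.08 log units; within the scatter). Compound 3 is estimated at 15 nM in this assay, with a range from 5 nM to 45 nM.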

Compound 3, half-maximal inhibitory concentration: 200 nM
Beside the measured number, compound 3's estimate is 13-fold (1.12 log units) below it; the whole stated range lies below it.
By their numbers in this assay, from the lowest: compound 2; then compounds 1 and 3 (each within the scatter of the next).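

This aromatic carbon, ortho to a chloro group and para to a large group, proves sensitive to the identity of its halogen: in this assay chloro in place of fluoro gives a 16-fold higher number from compound 2 to compound 3 (1.20 log units; beyond the scatter) and so costs much of the inhibition seen with compound 2. Among these compounds, the earlier compounds offered no single-place step, so this is the first direct reading of how much one atom can matter. Nothing at hand accounts for the size of this step.

The compounds shown carry only fluoro and chloro on this carbon, so it remains open how hydrogen, methyl or methoxy would read there. Among the compounds shown here, also open is whether the same exchange would give a step of similar size with a group other than the one shared by compound 2 and compound 3 on the tetrazole nitrogen.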